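The compounds below may be only part of what the source reports. "The series", "measured", "known", "first", "only" and "open" are said of these compounds alone.

For the measured compounds named here, compound 1 `C=C1C[C@]23C[C@@]1(O)CC[C@H]2c1ccc(O)c(C)c1[C@@H]3Cn1cc(-c2ccccn2)nn1` is one of two compounds measured so far in a functional assay on SW480 cells (Homo sapiens) for cytotoxicity, read by MTT assay, with a stated time of 4 days; a lower number here means a stronger inhibitor, a higher number a weaker inhibitor. In this assay compound 1 gives > 20000 nM, which is a limit of the assay rather than a number. Compound 2 `Cc1c(O)ccc2c1[C@H](Cn1cc(-c3ccc(Cl)cc3)nn1)[C@@]13CC(=O)[C@@](C)(CC[C@@H]21)C3`, built on a different core, likewise gives > 20000 nM in this assay, again a limit. Going by the values given here, the record therefore shows (the limit of > 20000 nM in this assay, at which 2 of the 2 values shown sit), so no measured step exists, and compound 1 stands at the limit together with compound 2, with nothing to rank the two. Compound 3 `C=C1C[C@]23C[C@@]1(O)CC[C@H]2c1ccc(O)c(C)c1[C@@H]3Cn1cc(-c2ccc(C(F)(F)F)cc2)nn1` differs from compound 1 by 4-(trifluoromethyl)phenyl in place of pyridin-2-yl on an aromatic carbon. The step from compound 1 to compound 3 in this assay is expected to be none beyond the scatter, a step that the limit leaves unreadable from compound 1 to compound 3. This expectation rests on compound 2, which also returned only > 20000 nM. Compound 3 is accordingly expected to come in near 30000 nM, with a range from 8000 nM to 100000 nM, most likely again as a limit.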

Compound 3, half-maximal inhibitory concentration: > 20000 nM
Compound 3: no number, only a limit; the forecaster's own chance of this, stated with the estimate: 75%; the middle value is on the limit's open side.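

In this assay no step can be read between compound 1 and compound 3, since both stand only at a limit: the limit of > 20000 nM in this assay, at which 3 of the 3 values shown sit. The compounds shown leave open how strong any of them is, and whether 4-(trifluoromethyl)phenyl in place of pyridin-2-yl changes the result at all.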